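This account rests on a few compounds, and the source may have more. Where it says the series, first, only, none or still open, it means among the compounds named here.

Compound 1 `Nc1cccc(CNc2cc(C(F)(F)F)cc3[nH]ncc23)c1` is measured in an assay for inhibition of Tryptophan 2,3-dioxygenase (Homo sapiens), with stated times of 10 min and 60 min (a higher number here means a weaker inhibitor, a lower number a stronger inhibitor), and gives 2510 nM. Compound 2 `O=C(O)CNc1cccc(CNc2cc(C(F)(F)F)cc3[nH]ncc23)c1` returns only a limit in this assay, > 100000 nM. The one measured step, an at least 39-fold higher number from compound 1 to compound 2 (1.60 log units; beyond the scatter), ends at the limit of > 100000 nM in this assay, at which 1 of the 2 values shown sits, so compound 2 stands at the weak edge of what is shown. Compound 3 `CNC(=O)c1cccc(CNc2cc(C(F)(F)F)cc3[nH]ncc23)c1` differs from compound 2 by methylcarbamoyl in place of (carboxymethyl)amino on an aromatic carbon. Within the data shown here, no measured step covers this exchange; the step from compound 1 to compound 2 shows only that the (carboxymethyl)amino group lost activity. Compound 3 is therefore expected to move back toward a number, by an at least 10-fold lower number from compound 2 to compound 3 (1.00 log units; beyond the scatter), with an estimate of 10000 nM and a range from 2000 nM to 60000 nM.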

Compound 3, half-maximal inhibitory concentration: 4870 nM
The estimate for compound 3 lay 2.1-fold (0.31 log units) above the measured number; measured number inside the range.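

In this assay, methylcarbamoyl on this aromatic carbon gives an at least 20-fold lower number from compound 2 to compound 3 (1.31 log units; beyond the scatter), so the loss seen with (carboxymethyl)amino does not extend to every group at this place. Against amino it gives a 1.9-fold higher number from compound 1 to compound 3 (0.29 log units; within the scatter), so these two groups cannot be told apart here. Compound 2 still has only a limit, not a number: the limit of > 100000 nM in this assay, at which 1 of the 3 values shown sits.

Going by these compounds, it remains open whether the loss belongs to the carboxylic acid or to the longer chain of (carboxymethyl)amino. On these data alone, how a methyl ester or a nitrile would read at this place also stays open.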